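This account rests on a few compounds, and the source may have more. Where it says the series, first, only, none or still open, it means among the compounds named here.

Compound 1 `Nc1nc(N)c2cc(CSC(=S)N3CCN(c4ccccc4F)CC3)ccc2n1`: 6660 nM
Compound 2 `CC(=O)c1ccc(N2CCN(C(=S)SCc3ccc4nc(N)nc(N)c4c3)CC2)cc1`: 2040 nM

Among the compounds with values here, in a functional assay on HeLa cells (Homo sapiens) for antiproliferative activity, read by MTT assay, with a stated time of 72 h (on this read-out higher numbers stand for weaker inhibition and lower numbers for stronger inhibition), compound 2 gives 2040 nM, the lower of the two numbers so far, while compound 1 gives 6660 nM. The next structure is compound 3 `Nc1nc(N)c2cc(CSC(=S)N3CCN(c4ccccn4)CC3)ccc2n1`, which differs from compound 2 as follows: pyridin-2-yl in place of 4-acetylphenyl on an amine nitrogen in a ring. In words, this puts pyridin-2-yl in place of 4-acetylphenyl on an amine nitrogen in a ring. Within the data shown here, only one measured step bears on this change, and it sits at the same place: a 3.3-fold lower number from compound 1 to compound 2 (0.51 log units; beyond the scatter). Among the measured compounds shown here, no measured compound carries pyridin-2-yl, so the direction remains uncertain. A step of similar size toward a higher number in this assay is the expectation, given that compound 2 holds the lower value. The expected change is a 2.0-fold higher number from compound 2 to compound 3 (0.29 log units; within the scatter). For compound 3, the estimated value is 4000 nM, with an expected range of 1500 nM to 10000 nM.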

Compound 3, half-maximal inhibitory concentration: 5090 nM
Estimate against measurement, compound 3: 1.3-fold (0.10 log units) below; the range from low to high includes it.
By their numbers in this assay, from the lowest: compound 2; then compounds 3 and 1 (each within the scatter of the next).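

In this assay the pyridin-2-yl group on the amine nitrogen in the ring does not match 4-acetylphenyl, with a 2.5-fold higher number from compound 2 to compound 3 (0.40 log units; beyond the scatter) as the step. Against 2-fluorophenyl the same group gives a 1.3-fold lower number from compound 1 to compound 3 (0.12 log units; within the scatter) and so cannot be told apart from it, which leaves compound 2 as the only one of the three with steps beyond the scatter to both others. Nothing measured on these compounds accounts for this difference.

On these data alone, whether the lower number of compound 2 belongs to the acetyl group or to its position on the ring remains open. An unsubstituted phenyl, a 3-acetylphenyl or a 4-methoxyphenyl group on the same nitrogen would speak to that question.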